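Hydroxymethyl in Place of Carboxy on the Shared Core

This account rests on a few compounds, and the source may have more. Where it says the series, first, only, none or still open, it means among the compounds named here.

Measured compounds in this series:
compound 1 `C/C=C/C(=O)Nc1ccc(Cn2nc(-c3ccc(Oc4ccccc4)cc3)cc2C(=O)O)cc1`: > 60000 nM
compound 2 `C=CC(=O)Nc1ccc(Cn2nc(-c3ccc(Oc4ccccc4)cc3)cc2C(=O)OCC)cc1`: 12500 nM
compound 3 `C/C=C/C(=O)Nc1cccc(Cn2nc(-c3ccc(Oc4ccccc4)cc3)cc2CO)c1`: 5700 nM

In a functional assay on Z-138 cells (Homo sapiens) for inhibition, read by luminescence and CellTiter-Glo, with a stated time of 72 h (on this read-out lower numbers stand for stronger inhibition and higher numbers for weaker inhibition), compound 1 gives > 60000 nM, which is a limit of the assay and not a number; (the limit of > 60000 nM in this assay, at which 1 of the 3 values shown sits). Compound 2 gives 12500 nM in this assay, and compound 3 gives 5700 nM. Compound 4 `C/C=C/C(=O)Nc1ccc(Cn2nc(-c3ccc(Oc4ccccc4)cc3)cc2CO)cc1` has not yet been measured. It differs from compound 1 by hydroxymethyl in place of carboxy on an aromatic carbon. Among the compounds with values here, no step between measured compounds is known here. Compound 4 is expected to be stronger than compound 1 by a step of an at least 10-fold lower number from compound 1 to compound 4 (1.00 log units; beyond the scatter) well beyond the scatter, since compound 3 carrying hydroxymethyl gives 5700 nM. The estimate for compound 4 is 6000 nM, within 1500 nM to 25000 nM.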

Compound 4, half-maximal inhibitory concentration: 54500 nM
Beside the measured number, compound 4's estimate is 9.1-fold (0.96 log units) below it; the whole stated range lies below it.
By their numbers in this assay, from the lowest: compound 3; then compound 2; then compound 4. At a limit, above all of these: compound 1.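

In this assay, hydroxymethyl in place of carboxy on an aromatic carbon gives an at least 1.1-fold lower number from compound 1 to compound 4 (0.04 log units; that floor lies within the scatter). On these data alone, compound 1 stands at a limit of the assay and not at a number, so the true size of this step stays unknown: the limit of > 60000 nM in this assay, at which 1 of the 4 values shown sits. Hydroxymethyl on the shared core does not by itself secure a low number: compound 4 gives 54500 nM, while compound 3, with the same group, gives 5700 nM.

The compounds shown leave open how an amine or a methoxymethyl group on this aromatic carbon would read in this assay.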